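Methoxy to hexyloxy on compound 2

The source may report more compounds than this note shows. Statements on the series, on what has been measured and on what is new or still open speak of the compounds shown alone.

In a functional assay on M21 cells (Homo sapiens) for antiproliferative activity, read by sulforhodamine B assay, with a stated time of 48 h (on this read-out higher numbers stand for weaker inhibition and lower numbers for stronger inhibition), compound 1 `O=C1NCCN1c1ccc(S(=O)(=O)Nc2ccc(I)cc2)cc1` gives 260 nM, while compound 2 `COc1ccc(NS(=O)(=O)c2ccc(N3CCNC3=O)cc2)cc1` gives 580 nM, the higher of the two numbers and so the weaker inhibition. Compound 3 `CCCCCCOc1ccc(NS(=O)(=O)c2ccc(N3CCNC3=O)cc2)cc1` keeps the core of compound 2 and differs in one group: pentyl in place of hydrogen on a saturated chain carbon bound to an oxygen on an aromatic ring, turning methoxy into hexyloxy. Among the compounds with values here, only one measured step bears on this, a 2.2-fold higher number from compound 1 to compound 2 (0.35 log units; beyond the scatter), which introduced the methoxy group in place of iodo. It lengthens no chain, so it offers only a rough guide to size, and the data do not settle the direction. A modest to moderate rise is nevertheless expected, and the estimated change is a 2.4-fold higher number from compound 2 to compound 3 (0.38 log units; beyond the scatter). For compound 3 the expected value is 1400 nM, with an estimated range of 350 nM to 5500 nM.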

Compound 3, half-maximal inhibitory concentration: > 1000 nM
Compound 3 was reported as a limit; the forecaster's own chance of this, stated with the estimate: 10%; the middle value does not contradict the limit.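

In this assay the reading for compound 3 is a limit of the assay and not a number: the limit of > 1000 nM in this assay, at which 1 of the 3 values shown sits. On these data alone, measured against the methoxy group, the change gives an at least 1.7-fold higher number from compound 2 to compound 3 (0.23 log units; that floor lies within the scatter), so adding pentyl at this saturated chain carbon brings no stronger inhibition, although how much weaker the inhibition becomes stays unknown. The comparison with the iodo group is firmer, with an at least 3.8-fold higher number from compound 1 to compound 3 (0.58 log units; beyond the scatter), and compound 1 remains the strongest of the three.

As far as these compounds go, the true value of compound 3 stays open, and with it whether inhibition falls steadily as the chain grows or drops sharply at some length. Also open, from the compounds shown here alone, is how an ethoxy or butoxy group, or a chain ending in an amine or a carboxylic acid, would read at this place.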